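Swapping Methoxy for Cyano: An Expected Inhibition Value

The compounds below may be only part of what the source reports. "The series", "measured", "known", "first", "only" and "open" are said of these compounds alone.

Three compounds have been measured in an assay for binding affinity to 17-beta-hydroxysteroid dehydrogenase type 2 (Homo sapiens), with a stated time of 20 min, tested at 1 uM; on this read-out higher numbers stand for more inhibition at the one concentration tested (going by the name of the read-out) and lower numbers for less inhibition:

compound 1 `Oc1cccc(-c2ccc3ccccc3c2)c1`: 12%
compound 2 `COc1ccc(-c2ccc3c(O)cccc3c2)cc1`: 20%
compound 3 `OCc1ccc(-c2ccc3c(O)cccc3c2)cc1`: 31%

Compound 2 stands second highest of the three numbers in this assay. Its nearest neighbour is compound 1, whose value lies within the scatter of that of compound 2, so the two cannot be ordered. The furthest is compound 3, reached by a number 11 percentage points higher from compound 2 to compound 3 (beyond the scatter), a modest rise beyond the scatter.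

The unmeasured compound 4 `N#Cc1ccc(-c2ccc3c(O)cccc3c2)cc1` differs from compound 2 by cyano in place of methoxy on an aromatic carbon. For the measured compounds named here, no measured step changes the methoxy into a cyano, so the only step that bears on it is the one from compound 2 to compound 3, where a group with a different shape took the same position and the number rose modestly. That step does not tell how a cyano will behave, but it shows that a change of group at that position went with a higher number rather than a lower one.

Compound 4 is therefore expected to sit close to compound 2, with the step of a number 5 percentage points higher from compound 2 to compound 4 (within the scatter) estimated to stay within or only just beyond the scatter. Compound 4 is estimated at 25%, with a range from 8% to 45%.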

Compound 4, a percentage reported as inhibition, at one concentration (the size of the read-out at that concentration, not a potency): 12%
Beside the measured number, compound 4's estimate is 13 percentage points above it, and the stated range covers the measured number.
By their numbers in this assay, from the lowest: compounds 1, 4 and 2 (each within the scatter of the next); then compound 3.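

In this assay, cyano in place of methoxy gives a number 8 percentage points lower from compound 2 to compound 4 (within the scatter), so at this position, on an aromatic carbon para to a large group, these two groups cannot be told apart, although one carries a triple bond and the other does not. Cyano in place of hydroxymethyl gives a number 19 percentage points lower from compound 3 to compound 4 (beyond the scatter), which shows that the higher number of compound 3 does not follow from just any replacement of methoxy here: of the two replacements shown, only hydroxymethyl gives a step beyond the scatter. Nothing available gives a measured reason why hydroxymethyl stands apart from cyano and methoxy.

The compounds shown leave open whether the higher number belongs to hydroxymethyl alone or would also appear with an aminomethyl group, a carboxylic acid or a longer chain such as hydroxyethyl in the same place. They also leave open whether these differences would hold at other concentrations, since each number is a reading at a single concentration and not a potency.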